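Methoxy removal on the aryl ether of the shared core

The compounds below may be only part of what the source reports. "The series", "measured", "known", "first", "only" and "open" are said of these compounds alone.

Three compounds with a shared core have been run in a functional assay on NCI cells (Homo sapiens) for inhibition; a higher number here means a weaker inhibitor, a lower number a stronger inhibitor. Compound 1 `COc1cccc(OC2=C(Cl)C(=O)c3c(OC(C)=O)ccc(OC(C)=O)c3C2=O)c1` gives 1000 nM in this assay. Compound 2 `COc1cc(OC)cc(OC2=C(Cl)C(=O)c3c(OC)ccc(OC)c3C2=O)c1` gives 1000 nM in this assay. Compound 3 `COc1cc(OC)cc(OC2=C(Cl)C(=O)c3c(OC(C)=O)ccc(OC(C)=O)c3C2=O)c1` gives 1000 nM in this assay. Compounds 1 and 3 differ in one counted place: hydrogen in place of methoxy on an aromatic carbon. The step of no change at the digits printed from compound 3 to compound 1 (within the scatter) is within the scatter of the method. Compound 2 stands level with compounds 1 and 3 at the digits read; its values against both lie within the scatter, and no order among the three can be drawn from them. How the core of compound 2 differs from that of compound 3 is not broken down here.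

Compound 4 `COc1cccc(OC2=C(Cl)C(=O)c3c(OC)ccc(OC)c3C2=O)c1` has not yet been measured in this assay. From compound 2 it differs by hydrogen in place of methoxy on an aromatic carbon. This is the same change as that from compound 3 to compound 1, at a place described in the same words, so it is taken as the same change rather than merely the same kind. Its one measured occurrence gave no movement, so the step from compound 2 to compound 4 is expected to be likewise flat, no change at the digits printed from compound 2 to compound 4 (within the scatter), because the earlier step of no change at the digits printed from compound 3 to compound 1 (within the scatter) stayed within the scatter. On that basis compound 4 is estimated at 1000 nM in this assay. The expected range for compound 4 runs from 500 nM to 2000 nM.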

Compound 4, half-maximal inhibitory concentration: 1000 nM
Compound 4: the middle estimate sits on the measured number at the digits printed, within the range that was stated.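

Working notes on the methoxy change. In this assay, hydrogen in place of methoxy on an aromatic carbon gives no change at the digits printed from compound 2 to compound 4 (within the scatter), so the change is flat on the core of compound 2 as well as on the core of compound 3. Set side by side, the two occurrences do not differ, and within this series the change carries from one core to the other without a visible difference: the same change on two cores in this assay, no change at the digits printed (within the scatter) from compound 3 to compound 1 and no change at the digits printed (within the scatter) from compound 2 to compound 4, 1.0-fold (0.00 log units) apart, within the scatter of two such steps. For the compounds shown here, this rests on only two cores and one position, however, and all four compounds print the same value, so it shows neither that the step would stay flat on a further core nor why it is flat, and it gives no order among the compounds.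

A flat step also says little about how a change that does move the value would transfer between these cores, so the transfer remains tested only for a change with no visible effect. Still open, on these data alone, is whether an amine or a carboxylic acid in place of the methoxy group, or a longer chain in place of its methyl part, would separate the two cores or shift the value on either one.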